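The compounds below may be only part of what the source reports. "The series", "measured", "known", "first", "only" and "open" are said of these compounds alone.

Two compounds have been measured in a functional assay on MCF7 cells (Homo sapiens) for antiproliferative activity, read by MTT assay, with a stated time of 72 h; a lower number here means a stronger inhibitor, a higher number a weaker inhibitor:
compound 1 `COc1ncc(-c2ccc3ncnc(NCCN4CCCCC4)c3c2)cc1C#N` gives 2740 nM;
compound 2 `COc1ncc(-c2ccc3ncnc(NCCN(C)C)c3c2)cc1C#N` gives 3230 nM.

Compound 1 has the lower of the two numbers, and the step of a 1.2-fold higher number from compound 1 to compound 2 (0.07 log units; within the scatter) shows that compound 1 and compound 2 sit within the scatter of each other. Compound 3 `COc1ncc(-c2ccc3ncnc(NCCN4CCCCC4)c3c2)cc1[N+](=O)[O-]` differs from compound 1 by nitro in place of cyano on an aromatic carbon. For the measured compounds named here, the single measured step, a 1.2-fold higher number from compound 1 to compound 2 (0.07 log units; within the scatter), changes a group on the saturated chain, not the aromatic ring altered here, so no measured step bears directly on this change. Compound 3 is therefore expected to stay near compound 1, a step of a 1.0-fold lower number from compound 1 to compound 3 (0.01 log units; within the scatter), with an estimated 2700 nM and a range from 900 nM to 8000 nM.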

Compound 3, half-maximal inhibitory concentration: 8610 nM
Compound 3: middle estimate off by 3.2-fold (0.50 log units), on the low side; the whole stated range lies below it.
By their numbers in this assay, from the lowest: compounds 1 and 2 (each within the scatter of the next); then compound 3.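

Nitro in place of cyano, a 3.1-fold higher number from compound 1 to compound 3 (0.50 log units; beyond the scatter) in this assay, shows that this aromatic position is sensitive to the group it carries. Of the two changes measured so far, only this one lies beyond the scatter, since the step on the saturated chain, a 1.2-fold higher number from compound 1 to compound 2 (0.07 log units; within the scatter), does not. No measurement shown gives a reason for this step and the size alone explains nothing.

On these data alone, whether a carboxylic acid, an amide or a trifluoromethyl group at this position would stay closer to compound 1 remains open. Also open, as far as these compounds go, is whether the same swap would have a similar effect on compound 2.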